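A few compounds are considered here, and "the series" means these few. Any claim that something is new, unique, unknown or untested is made for them only; others in the source may bear on it.

Compound 2 `NCCNC(=O)Cn1nc(N)c2c(C(F)(F)F)cc(-c3ccccc3)nc21` gives the higher of the two numbers in a functional assay on HeLa cells (Homo sapiens) for cytotoxicity, read by MTT assay, with a stated time of 24 h (on this read-out higher numbers stand for weaker inhibition and lower numbers for stronger inhibition), at 44500 nM; compound 1 `CCCNC(=O)Cn1nc(N)c2c(C(F)(F)F)cc(-c3ccccc3)nc21` gives 15900 nM, and a 2.8-fold higher number from compound 1 to compound 2 (0.45 log units; beyond the scatter). Compound 3 `Nc1nn(CC(=O)N2CCCC2)c2nc(-c3ccccc3)cc(C(F)(F)F)c12` differs from compound 2 in one place: pyrrolidin-1-yl in place of (2-aminoethyl)amino on a carbonyl carbon. Among the compounds with values here, only that one step bears on this change, and because a 2.8-fold higher number from compound 1 to compound 2 (0.45 log units; beyond the scatter) followed the arrival of the amino group that now departs within (2-aminoethyl)amino, compound 3 is expected to show a modest lower number in this assay, estimated as a 2.5-fold lower number from compound 2 to compound 3 (0.39 log units; beyond the scatter). Compound 3 is thus expected to give about 18000 nM, within a range from 6000 nM to 55000 nM.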

Compound 3, half-maximal inhibitory concentration: 16100 nM
Beside the measured number, compound 3's estimate is 1.1-fold (0.05 log units) above it, within the range that was stated.
By their numbers in this assay, from the lowest: compounds 1 and 3 (each within the scatter of the next); then compound 2.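

In this assay, a 2.8-fold lower number from compound 2 to compound 3 (0.44 log units; beyond the scatter) shows that the number falls again when (2-aminoethyl)amino gives way to pyrrolidin-1-yl on the carbonyl carbon. With a 1.0-fold higher number from compound 1 to compound 3 (0.01 log units; within the scatter), the ring and the propylamino group cannot be told apart, so among these three compounds only compound 2, with its (2-aminoethyl)amino group, stands apart, and no compound goes against this. Nothing available here explains these steps. On these data alone, how a (2-hydroxyethyl)amino or piperidin-1-yl group on that carbonyl carbon would read remains open.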